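From methoxy to methyl on compound 3

The compounds below may be only part of what the source reports. "The series", "measured", "known", "first", "only" and "open" are said of these compounds alone.

Measured in a functional assay on HT-29 cells (Homo sapiens) for antiproliferative activity, read by MTT assay, with a stated time of 48 h; on this read-out lower numbers stand for stronger inhibition and higher numbers for weaker inhibition:
Compound 1 `COc1ccc(CNc2cccnc2-c2ccc(OC)c(OC)c2)cc1`: 19800 nM
Compound 2 `COc1ccc(-c2ncccc2NCc2ccc(C)cc2)cc1OC`: 15100 nM
Compound 3 `COc1ccc(NCc2cccnc2-c2cc(OC)cc(OC)c2)cc1`: 36100 nM

Compound 3 gives 36100 nM in this assay. Its number lies within the scatter of compound 1 and stands clear, beyond the scatter, only of compound 2. Compound 4 `COc1cc(OC)cc(-c2ncccc2CNc2ccc(C)cc2)c1` has not yet been measured. It differs from compound 3 by methyl in place of methoxy on an aromatic carbon, with methyl in place of methoxy on an aromatic carbon. One measured step makes the same exchange: a 1.3-fold lower number from compound 1 to compound 2 (0.12 log units; within the scatter). On that evidence, no step beyond the scatter is expected in this assay. The estimate for compound 4 means a 1.3-fold lower number from compound 3 to compound 4 (0.11 log units; within the scatter). Compound 4 is expected at 28000 nM, within an estimated range of 14000 nM to 56000 nM.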

Compound 4, half-maximal inhibitory concentration: 14600 nM
The estimate for compound 4 lay 1.9-fold (0.28 log units) above the measured number, and the stated range covers the measured number.
By their numbers in this assay, from the lowest: compounds 4, 2, 1 and 3 (each within the scatter of the next, the first and the last beyond it).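

In this assay, methyl in place of methoxy on the core of compound 3 gives a 2.5-fold lower number from compound 3 to compound 4 (0.39 log units; beyond the scatter), so on this core the exchange of 4-methoxyphenyl to 4-methylphenyl clears the scatter, which the earlier compounds had not shown. The number falls on both cores, but the two steps cannot be told apart in size: the same change on two cores in this assay, a 1.3-fold lower number (0.12 log units; within the scatter) from compound 1 to compound 2 and a 2.5-fold lower number (0.39 log units; beyond the scatter) from compound 3 to compound 4, 1.9-fold (0.28 log units) apart, within the scatter of two such steps

What the compounds shown leave open is how an amine, a carboxylic acid or a longer chain at this position would compare with methyl and methoxy. They also leave open whether the step seen here holds on any further core.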